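Aryl for Ethyl on the Ring Nitrogen of Compound 3

The source may report more compounds than this note shows. Statements on the series, on what has been measured and on what is new or still open speak of the compounds shown alone.

Three compounds sharing one core were tested in a functional assay on MG-63 cells (Homo sapiens) for inhibition, read by CCK-8 assay, with a stated time of 72 h, tested at 1 uM; a higher number here means more inhibition at the concentration tested (going by the name of the read-out), a lower number less inhibition. Compound 1 `COc1ccc(C)cc1N1C(=O)CSC1c1cccc(C(=O)NCCCCc2ccccc2)c1` gives 92%, and compound 2 `O=C(NCCCCc1ccccc1)c1cccc(C2SCC(=O)N2c2cccc(F)c2)c1` gives 92%; these two carry different aromatic groups on the ring nitrogen, and the step of no change at the digits printed from compound 1 to compound 2 (within the scatter). Compound 3 `CCN1C(=O)CSC1c1cccc(C(=O)NCCCCc2ccccc2)c1`, which carries only an ethyl there, gives 0% and stands lowest of the three, far below both others.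

Compound 4 `COc1c(F)cccc1N1C(=O)CSC1c1cccc(C(=O)NCCCCc2ccccc2)c1` is not yet measured. Compared with compound 3 the change is 3-fluoro-2-methoxyphenyl in place of ethyl on an amide-type nitrogen in a ring. The measured steps that bear on this are the ones that run the other way: a number 92 percentage points lower from compound 1 to compound 3 (beyond the scatter) and a number 92 percentage points lower from compound 2 to compound 3 (beyond the scatter), each the loss of the whole signal when an aromatic group gives way to ethyl. Restoring an aromatic group on that nitrogen should therefore bring the signal back, and since the two aromatic groups already tested behaved alike, the exact substitution pattern seems to matter little.

For compound 4 a large rise is expected, a number 88 percentage points higher from compound 3 to compound 4 (beyond the scatter), to an estimated 88% with a likely range from 70% to 97%.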

Compound 4, a percentage reported as inhibition, at one concentration (the size of the read-out at that concentration, not a potency): 0%
The estimate for compound 4 lay 88 percentage points above the measured number; measured number below the stated range.
By their numbers in this assay, from the lowest: compounds 3 and 4 (each within the scatter of the next); then compounds 1 and 2 (each within the scatter of the next).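

Placing an aromatic ring on the amide-type nitrogen is not enough on its own: in this assay the swap of ethyl for 3-fluoro-2-methoxyphenyl gives no change at the digits printed from compound 3 to compound 4 (within the scatter) and leaves the signal absent. What decorates that aromatic ring therefore matters, since adding methoxy in place of hydrogen on an aromatic carbon gives a number 92 percentage points lower from compound 2 to compound 4 (beyond the scatter), and exchanging one methoxy-bearing aromatic group for another gives a number 92 percentage points lower from compound 1 to compound 4 (beyond the scatter), which shows that a methoxy group and a high signal can occur together and that methoxy alone does not account for the loss. Nothing available here explains why these closely related aromatic groups behave so differently.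

On these data alone, it remains open whether the loss in compound 4 depends on the fluorine and the methoxy group occurring together, or on the particular arrangement of these groups around the aromatic ring. A plain phenyl group, or a 2-methoxyphenyl group with no fluorine, on the same nitrogen would help separate these possibilities, as would a chlorine or an amino group in place of the fluorine.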